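The source may hold more compounds than are shown below. What is called first, only, known or untested is meant among the compounds shown, and "the series" means these compounds.

Measured so far:
compound 1 `C[Se]c1ccc2ccccc2n1`: > 100000 nM
compound 2 `O=C1c2ccccc2C(=O)N1CS`: > 100000 nM

In a functional assay on PC-3 cells (Homo sapiens) for cytotoxicity, read by MTT assay, with a stated time of 72 h (a lower number here means a stronger inhibitor of growth, a higher number a weaker inhibitor of growth), compound 1 gives only a limit, > 100000 nM. Compound 2 likewise gives only a limit in this assay, > 100000 nM. Both measured values sit at the limit of > 100000 nM in this assay, at which 2 of the 2 values shown sit, so compound 2 stands at the edge of what this assay reports rather than at a number. Compound 3 `N#CSCN1C(=O)c2ccccc2C1=O` differs from compound 2 by cyano in place of hydrogen on a sulfur. Within the data shown here, with no measured step to lean on, the change from compound 2 to compound 3 is expected to give a number no higher from compound 2 to compound 3 (the limit leaves the size open), nothing beyond the usual scatter. Compound 3 is expected at 100000 nM, with a range from 20000 nM to 300000 nM, most likely again only a limit.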

Compound 3, concentration for total growth inhibition: > 100000 nM
Compound 3: only a limit was reported; the forecaster's own chance of this, stated with the estimate: 70%; the middle value lies on the limit itself.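

Compound 2 and compound 3 each give only a limit, so no step can be read between them: the limit of > 100000 nM in this assay, at which 3 of the 3 values shown sit.

The compounds shown leave open what concentration, if any, gives a measurable value in this assay, and what cyano in place of hydrogen on a sulfur does to that value.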